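Oxime series: 3-cyanopyridin-2-yl replacing 4-methoxyphenyl

This account rests on a few compounds, and the source may have more. Where it says the series, first, only, none or still open, it means among the compounds named here.

Measured compounds:
compound 1 `N#Cc1cccnc1N1CCN(CC/C(=N\O)c2ccccc2)CC1` — 64%
compound 2 `CCO/N=C(\CCN1CCN(c2ccccc2C#N)CC1)c1ccccc1` — 82%
compound 3 `CCO/N=C(\CCN1CCN(c2ccc(OC)cc2)CC1)c1ccccc1` — 5%

In a functional assay on HEK293 cells with D(4) dopamine receptor (Homo sapiens) as the target, read by FLIPR (on this read-out higher numbers stand for larger maximal responses and lower numbers for smaller maximal responses), compound 2 gives 82% and compound 1 gives 64%. Compound 3 gives 5% in this assay, the lowest of the three numbers; its nearest neighbour is compound 1, and compound 2 is furthest away, both beyond the scatter.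

Among the measured compounds shown here, the only one-place step among the measured compounds is a number 77 percentage points lower from compound 2 to compound 3 (beyond the scatter), the change from 2-cyanophenyl to 4-methoxyphenyl on the ring nitrogen.

Compound 4 `CCO/N=C(\CCN1CCN(c2ncccc2C#N)CC1)c1ccccc1` has not yet been measured in this assay. It differs from compound 3 by 3-cyanopyridin-2-yl in place of 4-methoxyphenyl on an amine nitrogen in a ring. This reverses the direction of the measured step: a cyano-bearing aromatic ring returns to the ring nitrogen in place of 4-methoxyphenyl. The step of a number 77 percentage points lower from compound 2 to compound 3 (beyond the scatter) was large, so a large rise beyond the scatter is expected from compound 3 to compound 4. Compound 1 already carries 3-cyanopyridin-2-yl on that nitrogen and gives 64%, which points to where compound 4 may land. The estimated step is a number 60 percentage points higher from compound 3 to compound 4 (beyond the scatter). Compound 4 is expected to give about 65% in this assay, within a range of 40% to 85%.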

Compound 4, largest response reached (reported as efficacy), in percent of the reference or control that the assay uses: 64%
Estimate against measurement, compound 4: 1 percentage points above, and the stated range covers the measured number.
By their numbers in this assay, from the lowest: compound 3; then compounds 1 and 4 (each within the scatter of the next); then compound 2.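

On the amine nitrogen in a ring, this assay gives a number 59 percentage points higher from compound 3 to compound 4 (beyond the scatter) when 3-cyanopyridin-2-yl replaces 4-methoxyphenyl, so the low number of compound 3 is not fixed to the ethyl oxime series and a different nitrile-bearing ring can restore a large response. The two nitrile-bearing rings are not interchangeable at this place: 3-cyanopyridin-2-yl in place of 2-cyanophenyl gives a number 18 percentage points lower from compound 2 to compound 4 (beyond the scatter) in this assay and so a modest difference between them. Among the compounds shown here, with 3-cyanopyridin-2-yl held on the ring nitrogen, ethyl in place of hydrogen on the oxygen gives no change at the digits printed from compound 1 to compound 4 (within the scatter) in this assay and so offers the first direct reading of that oxygen, which shows no difference for this pair.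

No measurement beyond these responses is available to account for the steps, and their origin stays open. Also open, going by these compounds, is whether a propyl or benzyl group on that oxygen would read the same with 3-cyanopyridin-2-yl on the ring nitrogen, and whether a chloro or methyl group in place of the nitrile on that ring would retain the response of compound 4.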